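Outlook for Compound 3 After Swapping a Side Group

The compounds below may be only part of what the source reports. "The series", "measured", "known", "first", "only" and "open" are said of these compounds alone.

Compound 1 `CNCc1ccc2c(c1)nc(Cn1c(=O)n(C(C)C)c3ccccc31)n2CCC(C)C`: 1480 nM
Compound 2 `CC(=O)c1ccc2c(c1)nc(Cn1c(=O)n(C)c3ccccc31)n2CCC(C)C`: 5200 nM

In an ADME assay on HEp-2 cells (Homo sapiens) for cytotoxicity (a lower number here means that less compound is tolerated, a higher number that more compound is tolerated), compound 1 gives 1480 nM, the lowest of the two numbers, while compound 2 gives 5200 nM, a higher number that lies beyond the usual scatter. Compound 3 `CC(C)CCn1c(Cn2c(=O)n(C(C)C)c3ccccc32)nc2cc(-c3ncon3)ccc21` has not yet been measured. It differs from compound 1 in one place: 1,2,4-oxadiazol-3-yl in place of (methylamino)methyl on an aromatic carbon. Going by the values given here, no measured pair follows this change by itself, so the size of the step rests on expectation alone. The expected step of a 2.0-fold higher number from compound 1 to compound 3 (0.31 log units; beyond the scatter) points toward a higher number, though it could also fall within the scatter. For compound 3 the estimate is 3000 nM, ranging from 1000 nM to 9000 nM.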

Compound 3, half-maximal cytotoxic concentration: 223000 nM
For compound 3 the middle estimate is 74-fold (1.87 log units) below the measured one; the measured number lies above the stated range.
By their numbers in this assay, from the lowest: compound 1; then compound 2; then compound 3.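

In this assay, the change from (methylamino)methyl to 1,2,4-oxadiazol-3-yl gives a 150-fold higher number from compound 1 to compound 3 (2.18 log units; beyond the scatter), so this one aromatic carbon can by itself carry a large shift with the rest of the molecule held constant. Compound 1 and compound 2 differ in more than one place, so they could not show this. Nothing available explains the size of the step. Still open, on these data alone, is whether the step follows from the entering ring or from the departing (methylamino)methyl. As far as these compounds go, how a methyl group or a carboxylic acid on the same carbon would read also remains unknown.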